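Nitro analogue with a propoxy-linked imidazole

This account rests on a few compounds, and the source may have more. Where it says the series, first, only, none or still open, it means among the compounds named here.

Measured so far in a functional assay on NCI-H1975 cells (Homo sapiens) for antiproliferative activity, read by MTT assay, with a stated time of 48 h; on this read-out higher numbers stand for weaker inhibition and lower numbers for stronger inhibition:
Compound 1 `C=CC(=O)Nc1cccc(Nc2nc(Nc3ccc(OCCn4ccnc4)cc3)ncc2F)c1` gives 1810 nM.
Compound 2 `C=CC(=O)Nc1cccc(Nc2nc(Nc3ccc(-n4ccnc4)cc3)ncc2[N+](=O)[O-])c1` gives 12600 nM.

Of these two, compound 2 stands at the higher number, and the gap to compound 1 lies beyond the usual scatter, so compound 2 is the weaker inhibitor of the pair. Compound 3 `C=CC(=O)Nc1cccc(Nc2nc(Nc3ccc(OCCCn4ccnc4)cc3)ncc2[N+](=O)[O-])c1` has not been measured yet. It keeps the core of compound 2 and differs in one place: 3-(1H-imidazol-1-yl)propoxy in place of 1H-imidazol-1-yl on an aromatic carbon. Compound 1 also carries an imidazole tethered through an oxygen-containing chain rather than attached directly, and it gives the lower number, but compound 1 and compound 2 also differ elsewhere, so no clean step can be read from them. Among the compounds with values here, a moderate step in this assay toward a lower number is expected, a 2.5-fold lower number from compound 2 to compound 3 (0.40 log units; beyond the scatter), while the tether shared with compound 1 is the only guide. Compound 3 is estimated at 5000 nM, with a plausible range from 1500 nM to 15000 nM.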

Compound 3, half-maximal inhibitory concentration: 8320 nM
Estimate against measurement, compound 3: 1.7-fold (0.22 log units) below, within the range that was stated.
By their numbers in this assay, from the lowest: compound 1; then compounds 3 and 2 (each within the scatter of the next).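

In this assay, putting 3-(1H-imidazol-1-yl)propoxy in place of 1H-imidazol-1-yl on the aromatic carbon gives a 1.5-fold lower number from compound 2 to compound 3 (0.18 log units; within the scatter), so this single change cannot be told apart from the variation between repeated measurements. This position, para to a large group, therefore accepts a group of 9 heavy atoms instead of 5, including the added chain and its oxygen, with no clear shift in this read-out. No supporting measurement is available to explain this result.

Steps involving compound 1 cannot be read, as it differs from compound 2 and compound 3 in more than one place. Still open, from the compounds shown here alone, is how this core would respond to a longer chain such as a butoxy tether, or to a morpholine or dimethylamino group in place of the imidazole.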